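The compounds below may be only part of what the source reports. "The series", "measured", "known", "first", "only" and "open" are said of these compounds alone.

Of the compounds shown here, three built on one shared core have been tested in a functional assay on Bel-7402 cells (Homo sapiens) for antiproliferative activity, read by MTT assay, with a stated time of 72 h; on this read-out higher numbers stand for weaker inhibition and lower numbers for stronger inhibition. Compound 1 `C=C1C(=O)O[C@H]2[C@H]1CC/C(COC(=O)Cn1cc(F)c(=O)[nH]c1=O)=C\CC[C@@]1(C)O[C@@H]21` reads > 20000 nM, which is a limit of the assay and not a number. Compound 2 `C=C1C(=O)O[C@H]2[C@H]1CC/C(Cn1cc(Cn3cc(F)c(=O)[nH]c3=O)nn1)=C\CC[C@@]1(C)O[C@@H]21` reads > 20000 nM, also a limit. Compound 3 `C=C1C(=O)O[C@H]2[C@H]1CC/C(COC(=O)CCC(=O)N1CCN(C(=O)Cn3cc(F)c(=O)[nH]c3=O)CC1)=C\CC[C@@]1(C)O[C@@H]21` reads > 20000 nM, again a limit. Compound 2 therefore has no exact place on the scale, and it stands with the others at the limit of > 20000 nM in this assay, at which 3 of the 3 values shown sit.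

Compound 4 `C=C1C(=O)O[C@H]2[C@H]1CC/C(Cn1cc(Cn3cc(F)c(=O)n(Cc4ccccc4)c3=O)nn1)=C\CC[C@@]1(C)O[C@@H]21` alters compound 2 in a single place, with benzyl in place of hydrogen on an aromatic nitrogen. Among the measured compounds shown here, no pair of measured compounds shows what a change of this kind does in this assay. For the measured compounds named here, the only anchor is compound 2 at > 20000 nM, a limit. The expected step, an at least 1.3-fold lower number from compound 2 to compound 4 (0.12 log units; that floor lies within the scatter), is modest and toward stronger inhibition, and a reading that again gives only a limit is about as likely. For compound 4 the estimated value is 15000 nM, with an expected range from 4000 nM to 40000 nM.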

Compound 4, half-maximal inhibitory concentration: 9160 nM
Compound 4: middle estimate off by 1.6-fold (0.21 log units), on the high side, and the stated range covers the measured number.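

In this assay, the three earlier compounds all sat at a limit, so they could not show whether any change to this scaffold moves the reading. Benzyl in place of hydrogen on the aromatic nitrogen brings an at least 2.1-fold lower number from compound 2 to compound 4 (0.33 log units; beyond the scatter), so this position accepts a group of this size and the change goes toward stronger inhibition. That step is only a floor, and its true size stays unknown, as compound 2 has no exact value: the limit of > 20000 nM in this assay, at which 3 of the 4 values shown sit.

Going by these compounds, it remains open whether benzyl specifically matters or whether a methyl group, a longer alkyl chain or a benzyl carrying a chloro or methoxy group on its ring would read the same. Also open, on these data alone, is whether benzyl at this position would give an exact value on the linkers of compound 1 and compound 3.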